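The source may hold more compounds than are shown below. What is called first, only, known or untested is meant among the compounds shown, and "the series" means these compounds.

Compound 1 `CCCCCCCCCNC(=O)N(Cc1cc(OC)ccc1OC)n1cnnc1` was examined in a functional assay on MDA-MB-231 cells (Homo sapiens) for cytotoxicity, read by MTT assay, with a stated time of 48 h; on this read-out lower numbers stand for stronger inhibition and higher numbers for weaker inhibition. In this assay compound 1 gives only a limit, > 50000 nM, and no number. Compound 2 `COc1cc(CN(C(=O)Nc2ccc(C)cc2)n2cnnc2)cc(OC)c1OC` likewise reaches only a limit in this assay, > 50000 nM. Compound 3 `COc1ccc(CN(C(=O)Nc2ccc(Cl)cc2)n2cnnc2)cc1OC` also gives only a limit, > 50000 nM. Among the compounds with values here, compound 1 therefore stands where all three measured compounds stand, at the limit of > 50000 nM in this assay, at which 3 of the 3 values shown sit, so no measured step is available and no ordering among them can be drawn.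

Compound 4 `COc1ccc(OC)c(CN(C(=O)Nc2ccc(C)cc2)n2cnnc2)c1` differs from compound 1 by 4-methylphenyl in place of nonyl on an amide-type nitrogen. Compound 2 carries the same 4-methylphenyl group on its urea and gives only a limit, > 50000 nM. The expected step, a step that the limit leaves unreadable from compound 1 to compound 4, is none beyond the scatter. Compound 4 is thus expected to give about 70000 nM, within 20000 nM to 250000 nM, most likely reported again only as a limit.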

Compound 4, half-maximal inhibitory concentration: > 50000 nM
Compound 4: only a limit was reported; the forecaster's own chance of this, stated with the estimate: 80%; the middle value is on the limit's open side.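

In this assay, within the data shown here, compound 1 and compound 4 both give only a limit, so no step between them can be read: the limit of > 50000 nM in this assay, at which 4 of the 4 values shown sit. The compounds shown leave open which change to the shared core, if any, would give a measurable value.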